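Shifting Aryl Substituents in a Weakly Antiproliferative Series

This account rests on a few compounds, and the source may have more. Where it says the series, first, only, none or still open, it means among the compounds named here.

Compound 3 `COc1ccc(CNc2ncnc3c2ncn3[C@@H]2O[C@H](CO)[C@@H](O)[C@H]2O)c(OC)c1` bears a 2,4-dimethoxyphenyl on a saturated chain carbon bound to a nitrogen on an aromatic ring; in a functional assay on G-361 cells (Homo sapiens) for antiproliferative activity, with a stated time of 72 h (on this read-out higher numbers stand for weaker inhibition and lower numbers for stronger inhibition), compound 3 is recorded as "not determined" (no result reported), so its standing rests on its two neighbours with the shared core. Compound 1 `Cc1cccc(CNc2ncnc3c2ncn3[C@@H]2O[C@H](CO)[C@@H](O)[C@H]2O)c1` reaches only a limit of the assay: in this assay compound 1 gives > 166000 nM. Compound 2 `OC[C@H]1O[C@@H](n2cnc3c(NCc4ccc(Cl)cc4Cl)ncnc32)[C@H](O)[C@@H]1O` gives 128000 nM in this assay. For the measured compounds named here, the one measured step, an at least 1.2-fold lower number from compound 1 to compound 2 (0.11 log units; that floor lies within the scatter), stays within the scatter, and the weakness of the series is underlined by the limit of > 166000 nM in this assay, at which 1 of the 3 values shown sits.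

Compound 4 `COc1cccc(CNc2ncnc3c2ncn3[C@@H]2O[C@H](CO)[C@@H](O)[C@H]2O)c1O` differs from compound 3 in one place: 2-hydroxy-3-methoxyphenyl in place of 2,4-dimethoxyphenyl on a saturated chain carbon bound to a nitrogen on an aromatic ring. The incoming group brings one hydrogen-bond donor where the 2,4-dimethoxyphenyl had none; what that means for the read-out the data do not show. Going by the values given here, no measured step touches this pair directly. Because an at least 1.2-fold lower number from compound 1 to compound 2 (0.11 log units; that floor lies within the scatter) stays within the scatter even though the aryl groups of compound 1 and compound 2 differ strongly, compound 4 is expected to remain weak as well, with no shift beyond the scatter. For compound 4 the estimated value in this assay is 150000 nM, with a range from 50000 nM to 400000 nM.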

Compound 4, half-maximal inhibitory concentration: 148000 nM
The estimate for compound 4 lay 1.0-fold (0.01 log units) above the measured number; the range from low to high includes it.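

The 2-hydroxy-3-methoxyphenyl group adds a hydrogen-bond donor to this position, yet in this assay compound 4 cannot be told apart from the 2,4-dichlorophenyl of compound 2 (a 1.2-fold higher number from compound 2 to compound 4 (0.06 log units; within the scatter)). Set against the 3-methylphenyl, the same place gives an at least 1.1-fold lower number from compound 1 to compound 4 (0.04 log units; that floor lies within the scatter), and that comparison sets only a floor on the step. Compound 1 remains a limit of the assay and not a number, so three differently substituted aryl groups on this saturated chain carbon now yield no separation beyond the scatter, and the series stays weak: the limit of > 166000 nM in this assay, at which 1 of the 4 values shown sits.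

The compounds shown leave open whether an amine or a carboxylic acid on the aryl ring, or a longer chain in place of the benzylic link to the nitrogen on the aromatic ring, would bring the values out of this range. They also leave open whether the hydroxyl of compound 4 has any bearing of its own on the read-out, as the hydroxyl and the methoxy group enter together in every comparison available here.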